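Chalcone series: repositioning a methoxy group on the styryl ring

The source may hold more compounds than are shown below. What is called first, only, known or untested is meant among the compounds shown, and "the series" means these compounds.

Working notes. Two compounds have numbers in an assay on A549 cells for inhibition of transcription factor p65 (Homo sapiens), read by fluorescence, with a stated time of 2 h; on this read-out lower numbers stand for stronger inhibition and higher numbers for weaker inhibition. Compound 1 `COc1ccccc1/C=C/C(=O)c1cccc(-c2cccc(F)c2)c1` gives 35300 nM. Compound 2 `COc1ccc(-c2cc(C(=O)/C=C/c3cccc(OC)c3OC)ccc2N)cc1OC` gives 11900 nM, the lowest of the two numbers; the nearest is compound 1, whose number is higher by a margin that lies beyond the scatter, so compound 2 stands as the stronger inhibitor of this pair.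

Compound 3 `COc1ccc(/C=C/C(=O)c2ccc(N)c(-c3ccc(OC)c(OC)c3)c2)c(OC)c1` is not yet measured in this assay . It differs from compound 2 by one change: 2,4-dimethoxyphenyl in place of 2,3-dimethoxyphenyl on a double-bonded chain carbon bound to a double-bonded chain carbon. The two are the same atoms joined differently. Among the compounds with values here, no measured pair shows the effect of such a repositioning, so there is nothing to calibrate the step against.

The expectation for compound 3 is a change no larger than the scatter, in either direction, shown as a 1.2-fold lower number from compound 2 to compound 3 (0.08 log units; within the scatter). For compound 3 the estimate in this assay is 10000 nM, with a range from 3000 nM to 40000 nM.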

Compound 3, half-maximal inhibitory concentration: 1700 nM
Compound 3: the middle estimate sits 5.9-fold (0.77 log units) above what was measured, and the stated range ends above it.
By their numbers in this assay, from the lowest: compound 3; then compound 2; then compound 1.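

Repositioning alone matters at this place in this assay: 2,4-dimethoxyphenyl in place of 2,3-dimethoxyphenyl on a double-bonded chain carbon bound to a double-bonded chain carbon gives a 7.0-fold lower number from compound 2 to compound 3 (0.85 log units; beyond the scatter) with the atoms unchanged. Within the data shown here, the pair therefore shows that the arrangement of the two methoxy groups on this ring separates compound 2 from compound 3, which the earlier compounds could not show. No measurement bears on what lies behind the step.

Among these compounds, still open is whether this one step holds on the core of compound 1, as only a single pair speaks for it. Also open, as far as these compounds go, is how this assay responds to other groups on this ring, such as an amine or a carboxylic acid in place of either methoxy group.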